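The source may hold more compounds than are shown below. What is called first, only, known or untested is meant among the compounds shown, and "the series" means these compounds.

Measured so far in a functional assay on HCT-116 cells (Homo sapiens) for inhibition, read by CCK-8 assay, with a stated time of 48 h; a lower number here means a stronger inhibitor, a higher number a weaker inhibitor:
Compound 1 `COc1cc(-c2ccnc3cc(-c4ccc(C)cc4)nn23)cc(OC)c1OC` gives 48 nM.
Compound 2 `Cn1ccc2cc(-c3cc4nccc(-c5ccc(F)cc5)n4n3)ccc21` gives 2160 nM.
Compound 3 `COc1cc(-c2ccnc3c(-c4ccc(C)cc4)cnn23)cc(OC)c1OC` gives > 10000 nM, which is a limit of the assay rather than a number.

Compound 1 has the lowest of the two numbers shown in this assay; compound 2 stands far higher, a gap beyond the usual scatter of such measurements. Compound 3 reaches only (the limit of > 10000 nM in this assay, at which 1 of the 3 values shown sits), so for it no number is known. Compound 1 therefore stands out among the compounds already measured.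

Compound 4 `COc1cc(-c2ccnc3cc(-c4ccc(C(C)(C)C)cc4)nn23)cc(OC)c1OC` has not yet been measured. It differs from compound 1 in one place: tert-butyl in place of methyl on an aromatic carbon. The tert-butyl group enters where the methyl group leaves, on the same aromatic carbon, while the rest of the shared core and the trimethoxyphenyl group are unchanged.

Among the compounds with values here, no measured pair in this set shows a change of this kind, so there is no direct guide to how large the step will be. A bulkier group at this position might be tolerated or might cost some activity; the expectation here is for a modest weakening, with the step of a 3.1-fold higher number from compound 1 to compound 4 (0.49 log units; beyond the scatter) probably at the edge of the scatter. Compound 4 is thus estimated at 150 nM, with a likely range from 30 nM to 1200 nM.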

Compound 4, half-maximal inhibitory concentration: > 10000 nM
Compound 4 was reported as a limit (the forecaster's own chance of this, stated with the estimate: 10%); at least 66-fold (1.82 log units) between middle value and limit.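

In this assay, putting tert-butyl in place of methyl on this aromatic carbon gives an at least 200-fold higher number from compound 1 to compound 4 (2.31 log units; beyond the scatter), the first view of what a change at this place can cost. No hydrogen-bond donor, acceptor, ring or charge enters or leaves with this change, so the two groups differ only in their carbons, and that alone separates a compound with a clear activity from one with none that can be read here. The result for compound 4 is a limit of the assay and not a number, so only the lower end of the step is known, and the true gap could be larger: the limit of > 10000 nM in this assay, at which 2 of the 4 values shown sit.

Only methyl and tert-butyl are shown at this place, so it stays unknown where between them the activity is lost, and whether ethyl or isopropyl would hold close to compound 1, which gives 48 nM. On these data alone, it is also open how a group of another kind, such as a methoxy group, a chlorine atom or an amine, would fare on this same carbon.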